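The compounds below may be only part of what the source reports. "The series", "measured", "known", "first", "only" and "open" are said of these compounds alone.

Measured in an ADME assay on RAW264.7 cells (Mus musculus) for cytotoxicity, read by MTT assay, with a stated time of 48 h; on this read-out higher numbers stand for lower toxicity in this test and lower numbers for higher toxicity in this test:
Compound 1 `CCc1ccc(NC(=S)N/N=C\c2ccnc3ccccc23)cc1`: 35700 nM
Compound 2 `S=C(N/N=C\c1ccnc2ccccc12)Nc1ccc(Cl)cc1`: 63500 nM

Only these two compounds have been measured in this assay, and their values lie within the usual scatter of each other. Going by the values given here, compound 2, at 63500 nM, therefore cannot be told apart from compound 1, its only neighbour on the scale. The next compound to be tested is compound 3 `Cc1ccc(NC(=S)N/N=C\c2ccnc3ccccc23)cc1`, which carries methyl in place of chloro on an aromatic carbon, para to a large group: methyl in place of chloro on an aromatic carbon. In other words, 4-chlorophenyl gives way to 4-methylphenyl.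

Among the compounds with values here, one measured step bears on this change: a 1.8-fold higher number from compound 1 to compound 2 (0.25 log units; within the scatter). It exchanged ethyl for chloro on an aromatic carbon, so it is the closest available comparison, although it involves ethyl and not methyl. As that step stayed within the scatter, no step beyond the scatter is expected here, though a single pair is thin evidence. The expected change, slightly downward if anything, is a 1.4-fold lower number from compound 2 to compound 3 (0.15 log units; within the scatter). For compound 3 the expected value is 45000 nM, with an estimated range of 22000 nM to 90000 nM.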

Compound 3, half-maximal cytotoxic concentration: 50500 nM
Compound 3: middle estimate off by 1.1-fold (0.05 log units), on the low side; the measured number falls inside the stated range.
By their numbers in this assay, from the lowest: compounds 1, 3 and 2 (each within the scatter of the next).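

In this assay the exchange of 4-chlorophenyl for 4-methylphenyl gave a 1.3-fold lower number from compound 2 to compound 3 (0.10 log units; within the scatter) and so left methyl and chloro on an aromatic carbon, para to a large group, indistinguishable in this test. Going by these compounds alone, compound 3 also gave the first direct comparison of the two alkyl groups at this place: the change from ethyl to methyl gave a 1.4-fold higher number from compound 1 to compound 3 (0.15 log units; within the scatter) and, like the other two steps, stayed within the scatter, so no pair among ethyl, methyl and chloro can be told apart here. Nothing measured in this account offers an explanation for these values.

The three compounds therefore cover only ethyl, methyl and chloro at this one place, and it remains open whether a hydroxyl, an amine, a carboxylic acid or a longer chain there would also stay within the scatter of these compounds. Going by these compounds, the effect of changes elsewhere in the shared core also remains open, as does whether this flat picture would hold in any test other than this assay.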